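Semicarbazide series: replacing the aryl end with hydroxyethyl

The source may report more compounds than this note shows. Statements on the series, on what has been measured and on what is new or still open speak of the compounds shown alone.

Among the compounds with values here, the series so far holds two measured compounds. Within the data shown here, in a functional assay on SW-620 cells (Homo sapiens) for inhibition, read by MTT assay, with a stated time of 4 days (on this read-out lower numbers stand for stronger inhibition and higher numbers for weaker inhibition), compound 1 `COc1cc(NC(C)CCCNC(=O)NNC(=O)Nc2ccc(Cl)c(C(F)(F)F)c2)c2ncccc2c1` gives 15000 nM, the only actual number available. Compound 2 `CCOC(=O)NC(c1ccccc1)c1ccc(Cl)cc1` gives > 100000 nM, which is a limit of the assay and not a number. Compound 1 therefore has no numeric neighbour, and its place in the series cannot yet be ranked against a second measured value.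

The next compound is compound 3 `COc1cc(NC(C)CCCNC(=O)NNC(=O)NCCO)c2ncccc2c1`, which keeps the core of compound 1 and changes one end of the chain: 2-hydroxyethyl in place of 4-chloro-3-(trifluoromethyl)phenyl on an amide-type nitrogen. In words, 2-hydroxyethyl stands in place of 4-chloro-3-(trifluoromethyl)phenyl on an amide-type nitrogen, so the only aromatic ring of carbon in that end group is lost. Among the measured compounds shown here, no measured pair isolates this change, so the expectation is weakly anchored, resting on compound 1 at 15000 nM alone.

A step of a 2.3-fold higher number from compound 1 to compound 3 (0.37 log units; beyond the scatter) is expected in this assay, towards weaker inhibition and somewhat beyond the scatter. For compound 3 the estimated value is 35000 nM, with an expected range of 9000 nM to 100000 nM.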

Compound 3, half-maximal inhibitory concentration: > 100000 nM
Compound 3 gave a limit, no number (the forecaster's own chance of this, stated with the estimate: 25%); middle value at least 2.8-fold (0.45 log units) away from the limit.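

In this assay, within the data shown here, the first measured change at this position, 2-hydroxyethyl in place of 4-chloro-3-(trifluoromethyl)phenyl on an amide-type nitrogen, gives an at least 6.6-fold higher number from compound 1 to compound 3 (0.82 log units; beyond the scatter) and so moves towards weaker inhibition, beyond the scatter. Compound 3 reads > 100000 nM, which is a limit of the assay and not a number. The measurable inhibition of compound 1 is therefore not kept when this aryl end gives way to a chain with no ring, and the step can be read only as a minimum size because compound 3 stands at the limit shared with another compound: the limit of > 100000 nM in this assay, at which 2 of the 3 values shown sit.

The compounds shown leave open whether the loss follows from removing the six-membered aromatic ring of carbon or from removing its chlorine and trifluoromethyl substituents, and compound 1 at 15000 nM remains the only actual number in the series. A plain phenyl or a 4-chlorophenyl on the same nitrogen would separate these two readings, while a 2-aminoethyl or a longer alkyl chain would show whether any end group without a ring keeps a measurable value.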